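Cyclopropylmethyl in place of 4-methylbenzyl on the sulfur

A few compounds are considered here, and "the series" means these few. Any claim that something is new, unique, unknown or untested is made for them only; others in the source may bear on it.

Measured compounds:
compound 1, `Cc1cc(Nc2ccn(Cc3cccc4ccccc34)n2)n2nc(SCc3ccc(Br)cc3)nc2n1`, 4310 nM;
compound 2, `Cc1ccc(CSc2nc3nc(C)cc(Nc4cc(-c5ccccc5)[nH]n4)n3n2)cc1`, 7290 nM.

In a functional assay on MCF7 cells (Homo sapiens) for inhibition, read by MTT assay, with a stated time of 72 h (a lower number here means a stronger inhibitor, a higher number a weaker inhibitor), compound 2 gives the highest of the two numbers, and compound 1 lies within the usual scatter of it, so the two show no ordered difference. Compound 3, `Cc1cc(Nc2cc(-c3ccccc3)[nH]n2)n2nc(SCC3CC3)nc2n1`, has not been measured. It differs from compound 2 in one place: cyclopropyl in place of 4-methylphenyl on a saturated chain carbon bound to a sulfur. For the measured compounds named here, no step between measured compounds bears on this change, so only a small step from compound 2 is expected, perhaps toward a weaker inhibitor, as a 1.3-fold higher number from compound 2 to compound 3 (0.11 log units; within the scatter). Compound 3 is therefore estimated at 9500 nM, within 3000 nM to 30000 nM.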

Compound 3, half-maximal inhibitory concentration: > 50000 nM
Compound 3 ended at the assay's limit (the forecaster's own chance of this, stated with the estimate: 25%); middle value at least 5.2-fold (0.72 log units) from the limit.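

On the sulfur, this position proves sensitive to the group it carries: in this assay, cyclopropyl in place of 4-methylphenyl on a saturated chain carbon bound to a sulfur gives an at least 6.8-fold higher number from compound 2 to compound 3 (0.83 log units; beyond the scatter). The earlier compounds shown here differ in more than one place and gave no reading of this position. Compound 3 stands only as a limit of the assay, so the step has a lower bound but no full size: the limit of > 50000 nM in this assay, at which 1 of the 3 values shown sits.

The compounds shown leave open whether the aromatic ring itself or only the larger group matters here. They also leave open whether a longer chain such as n-butyl, or a pyridylmethyl group, on the sulfur would keep the number of compound 2.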